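Exchanging nitro for chloro on the aryl ring

This account rests on a few compounds, and the source may have more. Where it says the series, first, only, none or still open, it means among the compounds named here.

Compound 1 `CCO/C(O)=C1\C(C)=NC(C)=C(C(=O)OCCCN2C(=O)c3ccccc3S2(=O)=O)C1c1ccccc1[N+](=O)[O-]`: 2.6 nM
Compound 2 `COCCO/C(O)=C1\C(C)=NC(C)=C(C(=O)OCCCN2C(=O)c3ccccc3S2(=O)=O)C1c1ccccc1[N+](=O)[O-]`: 2.7 nM
Compound 3 `CC1=NC(C)=C(C(=O)OCCCN2C(=O)c3ccccc3S2(=O)=O)C(c2ccccc2[N+](=O)[O-])/C1=C(\O)OCC1CCCCO1`: 11.5 nM

All three compounds were tested in a functional assay (aorta) with Oryctolagus cuniculus as the target; a lower number here means a stronger inhibitor, a higher number a weaker inhibitor. Compound 2 sits with the second highest number of the three; its nearest neighbour is compound 1, and the step of a 1.0-fold higher number from compound 1 to compound 2 (0.02 log units; within the scatter) lies within the scatter, so the two cannot be told apart. Its furthest neighbour is compound 3, reached by the step of a 4.3-fold higher number from compound 2 to compound 3 (0.63 log units; beyond the scatter), a modest loss of potency.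

Compound 4 `COCCO/C(O)=C1\C(C)=NC(C)=C(C(=O)OCCCN2C(=O)c3ccccc3S2(=O)=O)C1c1ccccc1Cl` differs from compound 2 in a single place: chloro in place of nitro on an aromatic carbon. Going by the values given here, none of the measured steps touches this part of the molecule. The steps of a 1.0-fold higher number from compound 1 to compound 2 (0.02 log units; within the scatter) and a 4.4-fold higher number from compound 1 to compound 3 (0.65 log units; beyond the scatter) both alter the ester chain on the other side of the shared core, so they offer no direct guide to what a change on the aryl ring will do. The data therefore give no grounds to expect a large shift in either direction, and a step close to the scatter, or only a little beyond it, is the safest expectation.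

On that basis compound 4 is expected to give about 3.5 nM in this assay, within a range from 1 nM to 12 nM, which corresponds to an estimated step of a 1.3-fold higher number from compound 2 to compound 4 (0.11 log units; within the scatter).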

Compound 4, half-maximal inhibitory concentration: 2.9 nM
Beside the measured number, compound 4's estimate is 1.2-fold (0.08 log units) above it, and the stated range covers the measured number.
By their numbers in this assay, from the lowest: compounds 1, 2 and 4 (each within the scatter of the next); then compound 3.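

Exchanging 2-nitrophenyl for 2-chlorophenyl in this assay gives a 1.1-fold higher number from compound 2 to compound 4 (0.03 log units; within the scatter) and so leaves the two compounds indistinguishable. Going by these compounds alone, the earlier steps changed only the ester chain, whereas this one is the first to reach the aromatic carbon ortho to a large group, and it shows that a nitro group with 3 heavy atoms and 2 hydrogen-bond acceptors can give way to a chloro group with 1 heavy atom and no hydrogen-bond acceptors with no readable change in the number, so the nitro group is not needed for the low number of compound 4 in this assay. Nothing measured here explains why the number holds across this exchange.

This single exchange cannot say whether an amine or a carboxylic acid on the same aromatic carbon would keep the number in the same range, or whether a bare hydrogen there would do so. It also leaves open whether chloro would match nitro in the same way on the oxan-2-yl chain of compound 3, which gives 11.5 nM with the nitro group in place.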